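A Nitrile Gives Way to a Tetrazole

The source may report more compounds than this note shows. Statements on the series, on what has been measured and on what is new or still open speak of the compounds shown alone.

Measured so far:
Compound 1, `CSCc1cc(C(C)=O)c(O)cc1OCCCCCCC#N`: 97%
Compound 2, `C=CCc1cc(C(C)=O)c(O)cc1OCCCCCCCCC#N`: 86%
Compound 3, `CCc1cc(C(C)=O)c(O)cc1OCCCCC(C)(C)C#N`: 79%

All three compounds share one core and were tested in an assay on isolated protein for inhibition of leukotriene B4 receptor 1 (Homo sapiens), tested at 10 uM; on this read-out higher numbers stand for more inhibition at the one concentration tested (going by the name of the read-out) and lower numbers for less inhibition. Compound 3 gives the lowest of the three numbers. Its closest neighbour is compound 2, whose number lies within the usual scatter of repeated measurements, so the two cannot be told apart. Compound 1 stands furthest from compound 3, and that gap is beyond the scatter, so compound 1 inhibits more in this assay than compound 3 does.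

The next compound, compound 4, `CCc1cc(C(C)=O)c(O)cc1OCCCC(C)(C)c1nnn[nH]1`, has not yet been measured. It differs from compound 3 in one place: 1-(1H-tetrazol-5-yl)-1-methylethyl in place of 2-cyano-2-methylpropyl on a saturated chain carbon, three bonds along the chain from an oxygen on an aromatic ring. Among the measured compounds shown here, no pair of measured compounds differs in a single place, so no step of this kind has been seen here. With the nitrile and the tetrazole both placed at the end of the chain, the expectation is a small step, if any, either side of the scatter. Compound 4 is therefore estimated at 80%, between 55% and 97%, which means an expected step of a number 1 percentage points higher from compound 3 to compound 4 (within the scatter).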

Compound 4, a percentage reported as inhibition, at one concentration (the size of the read-out at that concentration, not a potency): 100%
Estimate against measurement, compound 4: 20 percentage points below; the measured number lies above the stated range.
By their numbers in this assay, from the lowest: compounds 3 and 2 (each within the scatter of the next); then compounds 1 and 4 (each within the scatter of the next).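

In this assay replacing 2-cyano-2-methylpropyl with 1-(1H-tetrazol-5-yl)-1-methylethyl gives a number 21 percentage points higher from compound 3 to compound 4 (beyond the scatter) in the first single-place change seen in this set, so the group on this saturated chain carbon, three bonds along the chain from an oxygen on an aromatic ring, does affect the read-out, and a five-membered aromatic ring is accepted there. The swap changes several things at once: the nitrile leaves, while a ring, more heavy atoms and a hydrogen-bond donor enter, and this single step cannot separate them. Nothing measured here bears on why the number rose.

Going by these compounds, whether a carboxylic acid at the end of the chain would match the tetrazole stays open, as does the outcome for a longer chain carrying the tetrazole. A reading at one concentration also leaves the potency of compound 4 unknown.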